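Chloro for bromo on the shared core: expected potency

The source may report more compounds than this note shows. Statements on the series, on what has been measured and on what is new or still open speak of the compounds shown alone.

Measured so far:
compound 1 `COc1ccc2[nH]c3c(c2c1)CCNC31CCN(Cc2ccc(F)cc2F)CC1`: 2000 nM
compound 2 `Fc1ccc(CN2CCC3(CC2)NCCc2c3[nH]c3ccc(Br)cc23)c(F)c1`: 21000 nM

In an assay on FRT cells for positive allosteric modulation of Cystic fibrosis transmembrane conductance regulator variant N1303K (Homo sapiens), in the presence of a further agent that is not named here (a higher number here means that more compound is needed for the effect, a lower number that less compound is needed), compound 1 gives 2000 nM, while compound 2 gives 21000 nM. For the measured compounds named here, compound 2 thus stands with the highest of the two numbers; its only neighbour is compound 1, and the single measured step, an 11-fold higher number from compound 1 to compound 2 (1.02 log units; beyond the scatter), lies beyond the scatter and is large.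

Compound 3 `Fc1ccc(CN2CCC3(CC2)NCCc2c3[nH]c3ccc(Cl)cc23)c(F)c1` differs from compound 2 by chloro in place of bromo on an aromatic carbon. Going by the values given here, the one step on record, an 11-fold higher number from compound 1 to compound 2 (1.02 log units; beyond the scatter), bears on this change only indirectly: it exchanges methoxy for bromo at the same place and says nothing about how two halogens compare. The swap of bromo for chloro is a smaller alteration than methoxy for bromo, so no step beyond the scatter is expected in this assay ; if anything, a slight drift toward the lower number of compound 1 cannot be ruled out.

Compound 3 is therefore expected to give about 15000 nM, with a range from 6000 nM to 40000 nM. This estimate means an expected step of a 1.4-fold lower number from compound 2 to compound 3 (0.15 log units; within the scatter).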

Compound 3, half-maximal effective concentration: 2500 nM
Compound 3: the middle estimate sits 6.0-fold (0.78 log units) above what was measured; measured number below the stated range.
By their numbers in this assay, from the lowest: compounds 1 and 3 (each within the scatter of the next); then compound 2.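

On the shared core, the aromatic carbon carrying the exchange does not treat the two halogens alike in this assay: replacing one heavy atom with another gives an 8.4-fold lower number from compound 2 to compound 3 (0.92 log units; beyond the scatter) and so separates chloro from bromo. Chloro and methoxy are not separated at this place, with a 1.3-fold higher number from compound 1 to compound 3 (0.10 log units; within the scatter) as the step between them, so among these three compounds bromo alone stands apart and the earlier 11-fold higher number from compound 1 to compound 2 (1.02 log units; beyond the scatter) cannot be read as a general effect of halogen in place of methoxy. Nothing available explains the gap between bromo and chloro at this position.

Still open, from the compounds shown here alone, is where fluoro, iodo or a nitrile on this same aromatic carbon would fall relative to chloro, methoxy and bromo, which would show whether bromo is an isolated case or one end of a wider trend. Also open, going by these compounds, is whether the gap between chloro and bromo persists when a second place on the shared core changes, for example with an amide or a carboxylic acid in a new substituent.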